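The source may hold more compounds than are shown below. What is called first, only, known or untested is meant among the compounds shown, and "the series" means these compounds.

Compound 1, `O=C(Nc1cccc(Cl)c1)O/N=C(\C1CCCCC1)C(Cc1ccccn1)C1CCCCC1`, gives 65 nM in a functional assay on E17 cells for antagonist activity at metabotropic glutamate receptor 5 (Rattus norvegicus), read by fluorescence and calcium flux; a lower number here means a stronger inhibitor, a higher number a weaker inhibitor.
Compound 2, `O=C(Nc1cccc(F)c1)O/N=C(\C1CCCCC1)C(Cc1cccs1)C1CCCCC1`, gives 46 nM in this assay.
Compound 3, `Cc1cccc(NC(=O)O/N=C(\C2CCCCC2)C(Cc2cccs2)C2CCCCC2)c1`, gives 48 nM in this assay.

Compound 1 shows the highest of the three numbers, yet its gaps to compound 3 and to compound 2 both sit within the scatter, so the three cannot be ordered. Compound 4, `O=C(Nc1cccc(Cl)c1)O/N=C(\C1CCCCC1)C(Cc1ccccc1)C1CCCCC1`, is still unmeasured and differs from compound 1 by phenyl in place of pyridin-2-yl on a saturated chain carbon, two bonds along the chain from a carbon with a double bond to nitrogen and a saturated ring carbon. Among the measured compounds shown here, the one measured step, a 1.0-fold higher number from compound 2 to compound 3 (0.02 log units; within the scatter), alters a group on an aromatic carbon elsewhere in the shared core and bears only loosely on this change; no measured pair shows pyridin-2-yl giving way to phenyl. Compound 4 is therefore expected to sit near compound 1, with an estimated step of no change at the digits printed from compound 1 to compound 4 (within the scatter) in this assay, within the scatter. Compound 4 is estimated at 65 nM, between 25 nM and 170 nM.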

Compound 4, half-maximal inhibitory concentration: 151 nM
Compound 4: middle estimate off by 2.3-fold (0.37 log units), on the low side, within the range that was stated.
By their numbers in this assay, from the lowest: compounds 2, 3 and 1 (each within the scatter of the next); then compound 4.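

Among the compounds shown here, at this saturated chain carbon, phenyl in place of pyridin-2-yl gives a 2.3-fold higher number from compound 1 to compound 4 (0.37 log units; beyond the scatter) in this assay, the first change in the set to go beyond the scatter. The earlier step, a 1.0-fold higher number from compound 2 to compound 3 (0.02 log units; within the scatter), stayed within it, so this position responds to a swap of one six-membered aromatic ring for another, at least on the core of compound 1. Nothing available explains this step.

The compounds shown leave open how a pyridin-3-yl group or a longer chain ending in an amine would read here. As far as these compounds go, it also stays open whether phenyl in place of pyridin-2-yl gives a similar step with fluoro or methyl in place of chloro.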